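A few compounds are considered here, and "the series" means these few. Any claim that something is new, unique, unknown or untested is made for them only; others in the source may bear on it.

Compound 1 `C[C@@H]1CCN(c2cc(-c3ccccc3)nc3ncnn23)C[C@@H]1N(C)c1ncnc2[nH]ccc12` gives > 100000 nM in a functional assay on HGC-27 cells (Homo sapiens) for inhibition, read by MTT assay, with a stated time of 72 h (on this read-out lower numbers stand for stronger inhibition and higher numbers for weaker inhibition), which is a limit of the assay and not a number.
Compound 2 `Cc1cc(N2CC[C@@H](C)[C@@H](N(C)c3ncnc4[nH]ccc34)C2)n2nc(SCc3csc4ccc(Cl)cc34)nc2n1` gives > 100000 nM in this assay, again a limit rather than a number.
Compound 3 `CCc1cc(N2CC[C@@H](C)[C@@H](N(C)c3ncnc4[nH]ccc34)C2)n2ncnc2n1` gives > 100000 nM in this assay, also a limit.

All three measured compounds share one core and sit at the same place: the limit of > 100000 nM in this assay, at which 3 of the 3 values shown sit. Compound 2 therefore stands nowhere in particular among them; its value is a limit, as are the two values around it. Among the compounds with values here, the only change between two measured compounds is a step that the two limits leave unreadable from compound 1 to compound 3. Both ends of that step are limits, and its size cannot be read.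

Compound 4 `Cc1cc(N2CC[C@@H](C)[C@@H](N(C)c3ncnc4[nH]ccc34)C2)n2nc(SCc3ccc(Br)cc3)nc2n1` is not yet measured. It differs from compound 2 by 4-bromophenyl in place of 5-chloro-1-benzothiophen-3-yl on a saturated chain carbon bound to a sulfur. Within the data shown here, no measured step touches this part of the molecule, and the one step that exists could not be read, so there is nothing here that would point to a gain or a loss in this assay beyond the usual scatter. Among the measured compounds shown here, the most that can be said is that every compound of this series so far has reached only the limit. For compound 4 the expected result in this assay is 100000 nM, with a range from 20000 nM to 500000 nM. The expected step is a number no higher from compound 2 to compound 4 (the limit leaves the size open), most likely again ending at a limit rather than a number.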

Compound 4, half-maximal inhibitory concentration: 19500 nM
For compound 4 the middle estimate is 5.1-fold (0.71 log units) above the measured one; the measured number lies below the stated range.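

Putting 4-bromophenyl in place of 5-chloro-1-benzothiophen-3-yl on a saturated chain carbon bound to a sulfur gives an at least 5.1-fold lower number from compound 2 to compound 4 (0.70 log units; beyond the scatter) in this assay, which makes this the first place in the series where a change can be seen as a number. Compound 2 gives > 100000 nM, a limit and not a number, so the real size of this step may be larger than the one printed. Within the data shown here, the group that enters has one six-membered aromatic ring of carbon only, while the group that leaves also carries a five-membered aromatic ring, so in this single pair the group with fewer heavy atoms is the one that gives a number.

Among these compounds, with only this pair at this position, and with the step between compound 1 and compound 3 unreadable, it stays open whether the bromine, the single ring or the smaller size of the group matters. From the compounds shown here alone, how an amine, a carboxylic acid or a longer chain on that same carbon would read also stays open, and the series offers few numbers to set any of this against: the limit of > 100000 nM in this assay, at which 3 of the 4 values shown sit.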